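Aryl variation on a shared alpha-ketooxazole core

The source may report more compounds than this note shows. Statements on the series, on what has been measured and on what is new or still open speak of the compounds shown alone.

Measured compounds:
compound 1, `Nc1ccccc1-c1cnc(C(=O)CCCCCCc2ccccc2)o1`, 750 nM
compound 2, `Nc1cccc(-c2cnc(C(=O)CCCCCCc3ccccc3)o2)c1`, 19 nM
compound 3, `O=C(CCCCCCc1ccccc1)c1ncc(-c2ccc(F)cc2)o1`, 62 nM

In an assay (Rattus norvegicus) for inhibition of Fatty-acid amide hydrolase 1 (Homo sapiens) (on this read-out higher numbers stand for weaker inhibition and lower numbers for stronger inhibition), compound 3 stands second highest of the three numbers, a 3.3-fold higher number from compound 2 to compound 3 (0.51 log units; beyond the scatter) and a 12-fold lower number from compound 1 to compound 3 (1.08 log units; beyond the scatter). Compound 4, `Cc1ccnc(-c2cnc(C(=O)CCCCCCc3ccccc3)o2)c1`, differs from compound 3 by 4-methylpyridin-2-yl in place of 4-fluorophenyl on an aromatic carbon. Among the measured compounds shown here, no measured step touches a pyridine; the steps that bear on this place, a 39-fold lower number from compound 1 to compound 2 (1.60 log units; beyond the scatter) and a 12-fold lower number from compound 1 to compound 3 (1.08 log units; beyond the scatter), show only that changing the group on this aromatic carbon can move the number far in either direction. Compound 4 is therefore expected to come out modestly lower, a 2.1-fold lower number from compound 3 to compound 4 (0.32 log units; beyond the scatter), with a wide range. The estimate for compound 4 in this assay is 30 nM, between 8 nM and 120 nM.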

Compound 4, inhibition constant: 0.6 nM
The estimate for compound 4 lay 50-fold (1.70 log units) above the measured number; the measured number lies below the stated range.
By their numbers in this assay, from the lowest: compound 4; then compound 2; then compound 3; then compound 1.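

In this assay, among the compounds shown here, the earlier compounds showed the number moving only among phenyl groups at this aromatic carbon. A six-membered aromatic ring with 1 hetero atom, bearing the same heavy-atom count as 4-fluorophenyl, takes the number below all of them (a 100-fold lower number from compound 3 to compound 4 (2.01 log units; beyond the scatter); a 32-fold lower number from compound 2 to compound 4 (1.50 log units; beyond the scatter); a 1300-fold lower number from compound 1 to compound 4 (3.10 log units; beyond the scatter)). Nothing shown accounts for this gain.

As far as these compounds go, how much of the step rests on the ring nitrogen and how much on the methyl remains open. A pyridin-2-yl group without the methyl, or a 4-methylphenyl group, would separate the two.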